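Three limits, one open analogue in the nitrooxy-chain series

A few compounds are considered here, and "the series" means these few. Any claim that something is new, unique, unknown or untested is made for them only; others in the source may bear on it.

Measured compounds:
compound 1 `COc1cc(/C=C/C(=O)OCCCO[N+](=O)[O-])ccc1OCCCO[N+](=O)[O-]` — in a functional assay on NCI-H460 cells (Homo sapiens) for cytotoxicity, read by resazurin assay, with a stated time of 72 h (a higher number here means a weaker inhibitor, a lower number a stronger inhibitor), compound 1 gives a limit, > 50000 nM.
compound 2 `O=C(/C=C/c1ccc(OCCCCCCO[N+](=O)[O-])c(O)c1)OCCCCCCO[N+](=O)[O-]` — here compound 2 gives a limit, > 50000 nM.
compound 3 `COc1cc(/C=C/C(=O)OCCCCCCO[N+](=O)[O-])ccc1OCCCCCCO[N+](=O)[O-]` — here compound 3 gives a limit, > 50000 nM.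

None of the three values in this assay is a number; each is a limit. The change from compound 3 to compound 2 is hydrogen in place of methyl on an oxygen on an aromatic ring, and the step it made, a step that the two limits leave unreadable from compound 3 to compound 2, cannot be read because of the limit of > 50000 nM in this assay, at which 3 of the 3 values shown sit. How the core of compound 1 differs from that of compound 3 is not broken down here.

Compound 4 `O=C(/C=C/c1ccc(OCCCO[N+](=O)[O-])c(O)c1)OCCCO[N+](=O)[O-]` has not been measured. It arises from compound 1 by hydrogen in place of methyl on an oxygen on an aromatic ring, the same change as from compound 3 to compound 2, at the same place. Compound 1 stands only at a limit, and the measured example of this change joins two limits, so the step from compound 1 to compound 4 is expected to stay unreadable, a step that the limit leaves unreadable from compound 1 to compound 4. For compound 4 the estimate is 60000 nM, with the expectation resting on (the limit of > 50000 nM in this assay, at which 3 of the 3 values shown sit), most likely again a limit rather than a number.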

Compound 4, half-maximal inhibitory concentration: 9580 nM
For compound 4 the middle estimate is 6.3-fold (0.80 log units) above the measured one, outside the stated range (below it).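

In this assay, methoxy to hydroxy on the core of compound 1 gives an at least 5.2-fold lower number from compound 1 to compound 4 (0.71 log units; beyond the scatter), and that size is only a minimum, as the starting point is a limit. On the other core, compound 2 remains a limit, at > 50000 nM. The step from compound 3 to compound 2 cannot be read, so the gain is shown on one core only, and whether the change carries from one core to the other is neither shown nor ruled out: the limit of > 50000 nM in this assay, at which 3 of the 4 values shown sit.

Still open, from the compounds shown here alone, is how the series responds to other groups in place of methoxy on the aromatic ring, such as ethoxy or an amine, when set against the hydroxy of compound 4. Also open, going by these compounds, is what happens when a carboxylic acid replaces the nitrooxy group at the chain ends of compound 4, which would test whether the hydroxy step depends on those ends.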